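Swapping the aryl group on the ring nitrogen

The source may hold more compounds than are shown below. What is called first, only, known or untested is meant among the compounds shown, and "the series" means these compounds.

Among the measured compounds shown here, in a functional assay on A549 cells (Homo sapiens) for antiproliferative activity, read by MTT assay, with a stated time of 24 h (on this read-out higher numbers stand for weaker inhibition and lower numbers for stronger inhibition), compound 2 `O=c1[nH]cc(S(=O)(=O)Nc2ccccc2-c2cn(-c3ccccc3F)nn2)c(=O)[nH]1` gives 7370 nM, the highest of the two numbers known here. For the measured compounds named here, compound 1 `Cc1ccccc1-n1cc(-c2ccccc2NS(=O)(=O)c2c[nH]c(=O)[nH]c2=O)nn1` gives 3210 nM, and the step of a 2.3-fold higher number from compound 1 to compound 2 (0.36 log units; beyond the scatter) is the only measured change. Compound 3 `O=c1[nH]cc(S(=O)(=O)Nc2ccccc2-c2cn(-c3ccc(Cl)cc3)nn2)c(=O)[nH]1` differs by 4-chlorophenyl in place of 2-fluorophenyl on an aromatic nitrogen. Going by the values given here, the step from compound 1 to compound 2 bears only loosely on this, since it also altered the same aryl ring but in a different way; no measured step matches the change to 4-chlorophenyl. A modest shift in either direction in this assay is plausible. Compound 3 is therefore expected near 5000 nM, between 1800 nM and 14000 nM, which would be a step of a 1.5-fold lower number from compound 2 to compound 3 (0.17 log units; within the scatter).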

Compound 3, half-maximal inhibitory concentration: 1180 nM
Estimate against measurement, compound 3: 4.2-fold (0.63 log units) above, outside the stated range (below it).
By their numbers in this assay, from the lowest: compound 3; then compound 1; then compound 2.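

With 4-chlorophenyl on the aromatic nitrogen, the series reaches its lowest number: the change gives a 6.2-fold lower number from compound 2 to compound 3 (0.80 log units; beyond the scatter), and against the methyl-bearing ring it gives a 2.7-fold lower number from compound 1 to compound 3 (0.43 log units; beyond the scatter). The aryl group at this position can therefore move the read-out further than the earlier fluoro-for-methyl swap did. Both the halogen and its place on the ring differ between 2-fluorophenyl and 4-chlorophenyl, so the step cannot be assigned to either, and no supporting data explain it. From the compounds shown here alone, how a methoxy group or an amine on this ring would compare remains open.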